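Methyl for Hydrogen on a Cyclic Dipeptide Side Chain

The compounds below may be only part of what the source reports. "The series", "measured", "known", "first", "only" and "open" are said of these compounds alone.

Compound 1 `CC[C@H](C)[C@@H]1C(=O)N[C@H](C2Cc3ccccc3C2)C(=O)N1[C@@H](C(=O)N1CCOCC1)c1ccc(C)nc1`: 1 mL.min-1.g-1
Compound 2 `CC[C@@H](C)[C@@H]1C(=O)N[C@H](C2Cc3ccccc3C2)C(=O)N1[C@@H](C(=O)N1CCOCC1)c1ccc(C)nc1`: 1 mL.min-1.g-1
Compound 3 `Cc1ccc([C@H](C(=O)N(C)C)N2C(=O)[C@@H](C3Cc4ccccc4C3)NC(=O)[C@H]2CC(C)C)cn1`: 3000 mL.min-1.g-1

In an in vitro ADME assay on microsomes from liver (Rattus norvegicus) for metabolic stability (on this read-out higher numbers stand for fast clearance and lower numbers for slow clearance), compound 3 gives 3000 mL.min-1.g-1, the highest of the three numbers, far beyond the scatter from either of the other two. Compound 4 `Cc1ccc([C@H](C(=O)N(C)C)N2C(=O)[C@@H](C3Cc4ccccc4C3)NC(=O)[C@H]2CC(C)(C)C)cn1` differs from compound 3 by methyl in place of hydrogen on a saturated chain carbon bound to three saturated chain carbons. Going by the values given here, the one measured step, no change at the digits printed from compound 1 to compound 2 (within the scatter), concerns a change of configuration only the fact that compounds 1 and 2 differ only in the configuration as drawn and says nothing about a methyl entering a side chain, so no measured step bears on this change. Without a precedent, the step of a 2.0-fold lower number from compound 3 to compound 4 (0.30 log units; within the scatter) is estimated as small relative to the scatter, in no firm direction. Compound 4 is therefore expected to give about 1500 mL.min-1.g-1, within 300 mL.min-1.g-1 to 6000 mL.min-1.g-1.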

Compound 4, intrinsic clearance in microsomes: 3 mL.min-1.g-1
Compound 4: the middle estimate sits 500-fold (2.70 log units) above what was measured, and the stated range ends above it.
By their numbers in this assay, from the lowest: compounds 1 and 2 (each within the scatter of the next); then compound 4; then compound 3.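

The step of a 1000-fold lower number from compound 3 to compound 4 (3.00 log units; beyond the scatter) in this assay is large, so on this saturated chain carbon a single methyl in place of hydrogen, which turns isobutyl into neopentyl, is far from a neutral change. Going by these compounds alone, the earlier compounds showed only a change of configuration, and this is the first measured step at this carbon that adds an atom. Nothing shown accounts for the size of the step. Going by these compounds, whether fluorine or hydroxyl in place of the same hydrogen would give a step of similar size remains open, as does the effect of a longer chain there.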